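This account rests on a few compounds, and the source may have more. Where it says the series, first, only, none or still open, it means among the compounds named here.

Measured in a functional assay for inhibition, with Homo sapiens as the target; a lower number here means a stronger inhibitor, a higher number a weaker inhibitor:

- compound 1 `COc1ccc(-c2nc(-c3ccc4c(c3)CCC(=O)N4)cs2)cc1OC`: 300 nM
- compound 2 `CCOc1ccc(-c2nc(-c3ccc4c(c3)CCC(=O)N4)cs2)cc1OCC`: 80 nM

Of these two compounds, compound 2 has the lower number, at 80 nM, which makes it the stronger inhibitor. Its gap to compound 1 lies beyond the usual scatter of repeated measurements.

The next compound to be tested is compound 3 `CCOc1ccc(-c2nc(-c3ccc4c(c3)CCC(=O)N4)cs2)cc1OC`. It differs from compound 2 by hydrogen in place of methyl on a saturated chain carbon bound to an oxygen on an aromatic ring, which turns ethoxy to methoxy.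

For the measured compounds named here, no measured step isolates this change, so the expectation rests only on the two known values. A move towards a higher number is expected in this assay, of moderate size and close to the edge of the scatter, without going past compound 1 at 300 nM. The expected change is a 2.0-fold higher number from compound 2 to compound 3 (0.30 log units; within the scatter). For compound 3 the estimated value is 160 nM, with an expected range from 70 nM to 350 nM.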

Compound 3, half-maximal inhibitory concentration: 600 nM
For compound 3 the middle estimate is 3.8-fold (0.57 log units) below the measured one; measured number above the stated range.
By their numbers in this assay, from the lowest: compound 2; then compounds 1 and 3 (each within the scatter of the next).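

In this assay the change from ethoxy to methoxy at this one place gives a 7.5-fold higher number from compound 2 to compound 3 (0.88 log units; beyond the scatter) and so, taken alone, accounts for the whole gap that separates compound 2 from compound 1. The other oxygen-bound chain reads differently: methyl in place of hydrogen there gives a 2.0-fold higher number from compound 1 to compound 3 (0.30 log units; within the scatter) and stays within the scatter, so with methoxy kept at this place a single ethoxy brings no readable gain, and the lower number of compound 2 appears only with ethoxy on both oxygens. Nothing measured here explains why the two places differ.

The compounds shown leave open how a longer chain such as propoxy, or a hydroxyl group, would read at this place, and so whether ethoxy is the best choice there or only better than methoxy. They also leave open how the exchanged arrangement would read, with the ethoxy and methoxy of compound 3 swapped, which would set the two places directly against each other.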